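The compounds below may be only part of what the source reports. "The series", "measured", "known", "first", "only" and "open" are said of these compounds alone.

Among the measured compounds shown here, compound 3 `COc1cc(-c2nnc3n2NC(c2ccco2)C(C(=O)c2ccccc2)S3)cc(OC)c1OC` is the only member of this set that gives a number in a functional assay on HepG2 cells (Homo sapiens) for cytotoxicity, read by MTT assay, with a stated time of 48 h (a higher number here means a weaker inhibitor, a lower number a stronger inhibitor), where compound 3 reaches 90900 nM. Compound 1 `COc1cc(-c2nnc3n2NC(c2ccco2)C(C(=O)c2ccc(C(F)(F)F)cc2)S3)cc(OC)c1OC`, which carries trifluoromethyl on the aromatic carbon, gives only a limit in this assay, > 100000 nM. Compound 2 `COc1cccc(C(=O)C2Sc3nnc(-c4cc(OC)c(OC)c(OC)c4)n3NC2c2ccco2)c1` likewise gives only a limit in this assay, > 100000 nM. For the measured compounds named here, the step from those limits to the one number is small: an at least 1.1-fold lower number from compound 1 to compound 3 (0.04 log units; that floor lies within the scatter), and an at least 1.1-fold lower number from compound 2 to compound 3 (0.04 log units; that floor lies within the scatter), both floors lying within the scatter, because two of the three values sit at the limit of > 100000 nM in this assay, at which 2 of the 3 values shown sit.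

Compound 4 `COc1cc(-c2nnc3n2NC(c2ccco2)C(C(=O)c2ccc(F)cc2)S3)cc(OC)c1OC` differs from compound 3 by fluoro in place of hydrogen on an aromatic carbon. The nearest measured step, that from compound 1 to compound 3, exchanges one group on that same aromatic carbon and shows at most a change within the scatter. On that basis compound 4 is expected to behave much like compound 3, with a step in this assay of about a 1.1-fold higher number from compound 3 to compound 4 (0.04 log units; within the scatter), no more than the scatter. For compound 4 the estimated value in this assay is 100000 nM, with a range from 45000 nM to 250000 nM, and a real chance that only a limit is reported.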

Compound 4, half-maximal inhibitory concentration: > 100000 nM
Compound 4 gave a limit, no number; the forecaster's own chance of this, stated with the estimate: 55%; the middle value lies on the limit itself.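

Fluoro in place of hydrogen on the aromatic carbon para to a large group gives, in this assay, an at least 1.1-fold higher number from compound 3 to compound 4 (0.04 log units; that floor lies within the scatter). That aromatic carbon has now been shown with hydrogen, fluoro and trifluoromethyl, in compound 3, compound 4 and compound 1, and no readable step among them passes beyond the scatter. The steps to compound 4 from compound 1 and from compound 2 cannot be read, because both ends of each are limits and the set gathers at the edge of the assay: the limit of > 100000 nM in this assay, at which 3 of the 4 values shown sit.

From the compounds shown here alone, how far compound 1, compound 2 and compound 4 lie past that limit stays open, so these three cannot be ranked against one another. Going by these compounds, whether an amine or a carboxylic acid on that same aromatic carbon would shift the value of compound 3, 90900 nM, beyond the scatter also stays open.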